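The source may report more compounds than this note shows. Statements on the series, on what has been measured and on what is new or still open speak of the compounds shown alone.

Among the measured compounds shown here, compound 2, `Oc1ccccc1-c1cc(-c2ccccc2C(F)(F)F)cc(-c2ccccc2O)n1`, is the one compound here with a number: in a functional assay on DU-145 cells (Homo sapiens) for inhibition (on this read-out lower numbers stand for stronger inhibition and higher numbers for weaker inhibition), compound 2 gives 4770 nM. The other measured compound, compound 1 with structure `Oc1ccc(-c2cc(-c3ccccc3F)cc(-c3ccccc3O)n2)cc1`, gives only a limit, > 50000 nM, in this assay. The pair shows (the limit of > 50000 nM in this assay, at which 1 of the 2 values shown sits). For the measured compounds named here, no step between two measured compounds is known, so the change that leads to compound 3, `Oc1ccc(-c2cc(-c3ccccc3C(F)(F)F)cc(-c3ccccc3O)n2)cc1`, has to be judged on its own: 4-hydroxyphenyl in place of 2-hydroxyphenyl on an aromatic carbon. Compound 1 carries the same pairing of a 4-hydroxyphenyl with a 2-hydroxyphenyl and sits at the limit of this assay, so the same swap on compound 2 is expected to weaken inhibition, and from compound 2 to compound 3 a drop beyond the scatter is expected, a 4.2-fold higher number from compound 2 to compound 3 (0.62 log units; beyond the scatter). Compound 3 is therefore estimated at 20000 nM, plausibly between 5000 nM and 60000 nM, with a fair chance that only a limit is reported.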

Compound 3, half-maximal inhibitory concentration: 6690 nM
Beside the measured number, compound 3's estimate is 3.0-fold (0.48 log units) above it; the range from low to high includes it.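

In this assay, the step at the ring carbon next to the ring nitrogen is small: a 1.4-fold higher number from compound 2 to compound 3 (0.15 log units; within the scatter). With a 2-(trifluoromethyl)phenyl group in place, 4-hydroxyphenyl and 2-hydroxyphenyl therefore cannot be told apart at this position. The clear step lies at the other place that differs, with trifluoromethyl in place of fluoro: an at least 7.4-fold lower number from compound 1 to compound 3 (0.87 log units; beyond the scatter); its size has only a lower bound, since compound 1 stands as a limit and not a number: the limit of > 50000 nM in this assay, at which 1 of the 3 values shown sits.

As far as these compounds go, whether a 4-aminophenyl or 4-methoxyphenyl group would hold inhibition at this position stays open. So does whether trifluoromethyl in place of fluoro gives a similar step when 2-hydroxyphenyl occupies this position, or how a chloro group would compare at the same place.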